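A few compounds are considered here, and "the series" means these few. Any claim that something is new, unique, unknown or untested is made for them only; others in the source may bear on it.

Working notes on the series, read in a functional assay on HT-29 cells (Homo sapiens) for inhibition; a higher number here means a weaker inhibitor, a lower number a stronger inhibitor. Compound 1 (`COc1cc(/C=C\c2ccc3c(ccn3S(=O)(=O)c3ccccc3)c2)cc(OC)c1OC`) gives > 5000 nM, and this is a limit of the assay, not a number. Going by the values given here, compound 2 (`COc1cc(/C=C/c2ccc3[nH]ccc3c2)cc(OC)c1OC`) gives 280 nM, the only actual number so far.

The next compound to read is compound 3 (`COc1cc(/C=C\c2ccc3[nH]ccc3c2)cc(OC)c1OC`). The change is the two compounds have the same atoms and bonds and differ only in configuration as drawn: 1 of 1 stereo elements differ; a double bond is drawn E in compound 2 and Z in compound 3. The two compounds have the same atoms and bonds, and a double bond is drawn E in compound 2 and Z in compound 3.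

Among the compounds with values here, no measured pair isolates this change, so the size of the step is a judgement and not a reading from the data. The range is kept wide for that reason. The expected move in this assay is towards a lower number, beyond the scatter, with the step estimated as a 4.7-fold lower number from compound 2 to compound 3 (0.67 log units; beyond the scatter). The starting point for that expectation is compound 2 at 280 nM. For compound 3 the expected value is 60 nM, with an estimated range from 10 nM to 400 nM.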

Compound 3, half-maximal inhibitory concentration: 35 nM
Estimate against measurement, compound 3: 1.7-fold (0.23 log units) above; the measured number falls inside the stated range.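

In this assay, the configuration of the double bond alone gives an 8.0-fold lower number from compound 2 to compound 3 (0.90 log units; beyond the scatter), and the Z form carries the lower number. The whole step can be assigned to the configuration because nothing else changes: the fact that compounds 2 and 3 differ only in the configuration as drawn. With the Z double bond kept, hydrogen in place of phenylsulfonyl on the aromatic nitrogen gives an at least 140-fold lower number from compound 1 to compound 3 (2.15 log units; beyond the scatter), although compound 1 gives > 5000 nM, a limit and not a number, and this step is therefore only a bound: the limit of > 5000 nM in this assay, at which 1 of the 3 values shown sits.

The compounds shown leave open how a substituent of intermediate size on the aromatic nitrogen, such as methyl or acetyl, would read against hydrogen and phenylsulfonyl with the Z double bond kept. Also open, from the compounds shown here alone, is whether a methoxy group on the shared core could be exchanged for a hydroxyl or an amine without losing the low number of compound 3, as all three compounds carry the same methoxy groups and give no reading on them.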